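A few compounds are considered here, and "the series" means these few. Any claim that something is new, unique, unknown or untested is made for them only; others in the source may bear on it.

In a functional assay on P388 cells (Mus musculus) for cytotoxicity (on this read-out higher numbers stand for weaker inhibition and lower numbers for stronger inhibition), compound 1 `COc1cccc(Cc2cn(C3CC3)c3c(F)c(-c4cc(C)nc(C)c4)c(F)cc3c2=O)c1` gives 20000 nM, compound 2 `Cc1cc(-c2c(F)cc3c(=O)c(Cc4ccc[nH]4)cn(C4CC4)c3c2F)cc(C)n1` gives 930 nM and compound 3 `Cc1cc(-c2c(F)cc3c(=O)c(Cc4ccccc4N)cn(C4CC4)c3c2F)cc(C)n1` gives 2100 nM. Compound 3 thus holds the middle of the three numbers, much nearer to compound 2 than to compound 1. Still unmeasured is compound 4 `Cc1cc(-c2c(F)cc3c(=O)c(Cc4ncc[nH]4)cn(C4CC4)c3c2F)cc(C)n1`, which carries 1H-imidazol-2-yl in place of 2-aminophenyl on a saturated chain carbon bound to an aromatic carbon.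

Two measured steps start from 3-methoxyphenyl, a 22-fold lower number from compound 1 to compound 2 (1.33 log units; beyond the scatter) and a 9.5-fold lower number from compound 1 to compound 3 (0.98 log units; beyond the scatter), and both run toward lower numbers. The closest guide is a 2.3-fold higher number from compound 2 to compound 3 (0.35 log units; beyond the scatter), as compound 2 also bears a five-membered aromatic ring. Read in reverse, that modest step suggests a small move toward a lower number for compound 4. Among the measured compounds shown here, no measured compound carries 1H-imidazol-2-yl, so the range stays wide. In this assay the estimated step is a 1.6-fold lower number from compound 3 to compound 4 (0.21 log units; within the scatter), not expected to exceed the scatter. For compound 4 the estimate is 1300 nM, with an expected range of 350 nM to 6000 nM.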

Compound 4, half-maximal inhibitory concentration: 1100 nM
The estimate for compound 4 lay 1.2-fold (0.07 log units) above the measured number; measured number inside the range.
By their numbers in this assay, from the lowest: compounds 2, 4 and 3 (each within the scatter of the next, the first and the last beyond it); then compound 1.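

In this assay, 1H-imidazol-2-yl on this saturated chain carbon also gives a large step away from 3-methoxyphenyl, an 18-fold lower number from compound 1 to compound 4 (1.26 log units; beyond the scatter). The ring swaps at the other end of the series give no readable difference: a 1.2-fold higher number from compound 2 to compound 4 (0.07 log units; within the scatter) and a 1.9-fold lower number from compound 3 to compound 4 (0.28 log units; within the scatter) both stay within the scatter, so compound 4 cannot be separated from either neighbour, although compound 2 and compound 3 are separated from each other. Nothing available explains these steps.

Still open, as far as these compounds go, is whether the ring hydrogen or amino hydrogen goes with the lower numbers relative to compound 1. A plain phenyl or a 1-methyl-1H-imidazol-2-yl group on the same carbon would address this, and a longer chain carrying the imidazole would show whether the single carbon link matters.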